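Toward compound 4: heptyl for 4-bromophenyl

This account rests on a few compounds, and the source may have more. Where it says the series, first, only, none or still open, it means among the compounds named here.

Measured in a functional assay on MCF7 cells (Homo sapiens) for inhibition, read by MTT assay, with a stated time of 48 h; a lower number here means a stronger inhibitor, a higher number a weaker inhibitor:
Compound 1 `COc1ccc(C(c2c[nH]c3ccc(Br)cc23)c2c[nH]c3ccc(Br)cc23)cc1`: 2300 nM
Compound 2 `CN(C)c1ccc(C(c2c[nH]c3ccc(Br)cc23)c2c[nH]c3ccc(Br)cc23)cc1`: 24900 nM
Compound 3 `O=[N+]([O-])c1ccc2[nH]cc(C(c3ccc(Br)cc3)c3c[nH]c4ccc([N+](=O)[O-])cc34)c2c1`: > 100000 nM

Compound 3 stands at > 100000 nM, which is a limit of this assay and not a number. Compound 4 `CCCCCCCC(c1c[nH]c2ccc([N+](=O)[O-])cc12)c1c[nH]c2ccc([N+](=O)[O-])cc12` differs from it by heptyl in place of 4-bromophenyl on a saturated chain carbon bound to two aromatic carbons. Going by the values given here, the only measured step, an 11-fold higher number from compound 1 to compound 2 (1.03 log units; beyond the scatter), is large, but it concerns another change on the core of compound 1, so it bears only loosely. It shows that a single change can move the number a long way. A small move toward a lower number is expected, with an at least 1.4-fold lower number from compound 3 to compound 4 (0.15 log units; that floor lies within the scatter) as the estimated step. The expected value for compound 4 is 70000 nM, with an estimated range of 15000 nM to 200000 nM.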

Compound 4, half-maximal inhibitory concentration: 5800 nM
Compound 4: the middle estimate sits 12-fold (1.08 log units) above what was measured; measured number outside the range, below it.
By their numbers in this assay, from the lowest: compound 1; then compound 4; then compound 2. At a limit, above all of these: compound 3.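

In this assay, the change at this saturated chain carbon gives an at least 17-fold lower number from compound 3 to compound 4 (1.23 log units; beyond the scatter), so this position alone can carry a large step, and a measurable number does not depend on an aromatic ring there. Compound 3 sits at a limit of the assay and not at a number, so the size of this step is only a floor: the limit of > 100000 nM in this assay, at which 1 of the 4 values shown sits.

Open, as far as these compounds go, is whether the step depends on chain length, which a shorter chain, a longer chain or a cyclohexyl ring at this carbon would test. Also open, from the compounds shown here alone, is whether heptyl gives a similar step on the core of compound 1.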